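The source may report more compounds than this note shows. Statements on the series, on what has been measured and on what is new or still open speak of the compounds shown alone.

Compound 1 `CCn1cc(C(=O)O)c(=O)c2cc(F)c(N3CCN(S(=O)(=O)c4ccc(Cl)cc4)CC3)cc21`: 2630 nM
Compound 2 `CCn1cc(C(=O)O)c(=O)c2cc(F)c(N3CCN(S(=O)(=O)c4ccc(Cl)cc4Cl)CC3)cc21`: 2630 nM

In a functional assay on cells (Panel NCI-60 (60 carcinoma cell lines), Homo sapiens) for inhibition, read by sulforhodamine B assay, with a stated time of 48 h (on this read-out lower numbers stand for stronger inhibition of growth and higher numbers for weaker inhibition of growth), compound 2 gives 2630 nM, level with compound 1 at the digits shown. Compound 3 `CCn1cc(C(=O)O)c(=O)c2cc(F)c(N3CCN(S(=O)(=O)c4cccc5ccccc45)CC3)cc21` has naphthalen-1-yl in place of 2,4-dichlorophenyl on a sulfonyl sulfur. Within the data shown here, only one measured step bears on this change, no change at the digits printed from compound 1 to compound 2 (within the scatter), where chloro replaces hydrogen on an aromatic carbon. Among the measured compounds shown here, that step stays within the scatter, but it is a much smaller edit than replacing the whole group, and no measured compound carries a naphthalen-1-yl group. The data therefore point to no particular direction, and no shift beyond the scatter is expected in this assay. The expected step is a 1.0-fold lower number from compound 2 to compound 3 (0.00 log units; within the scatter). Compound 3 is estimated at 2600 nM, with an expected range from 1000 nM to 6500 nM.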

Compound 3, concentration for 50% growth inhibition: 2630 nM
Compound 3: the middle estimate sits 1.0-fold (0.00 log units) below what was measured; the measured number falls inside the stated range.
By their numbers in this assay, from the lowest: compounds 1, 2 and 3 (each within the scatter of the next).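

In this assay, naphthalen-1-yl in place of 2,4-dichlorophenyl on a sulfonyl sulfur gives no change at the digits printed from compound 2 to compound 3 (within the scatter), and naphthalen-1-yl in place of 4-chlorophenyl gives no change at the digits printed from compound 1 to compound 3 (within the scatter). Among these compounds, this position had so far been probed only by one added chloro, and it now also accepts an exchange of the whole group, with a second six-membered aromatic ring entering and the chlorine atoms leaving, and the number stays where it was. Nothing available explains this flat result.

The compounds shown leave open whether a non-aromatic group on the sulfonyl sulfur, such as methyl or cyclohexyl, or an aromatic ring carrying an amine or a carboxylic acid, would shift the number in this assay. They also leave open what a carbonyl in place of the sulfonyl would do.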